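This account rests on a few compounds, and the source may have more. Where it says the series, first, only, none or still open, it means among the compounds named here.

Compound 1 `O=C(NCCCOc1cccc(CN2CCCCC2)c1)Nc1cccc(C(F)(F)F)c1` gives 813 nM in an assay on isolated protein for inhibition of histamine H2 receptor (Cavia porcellus); a higher number here means weaker binding, a lower number tighter binding; compound 2 `CNC(=O)NCCCOc1cccc(CN2CCCCC2)c1` gives 155 nM in this assay.

Compound 2 thus holds the lower of the two numbers, and the step of a 5.2-fold lower number from compound 1 to compound 2 (0.72 log units; beyond the scatter) lies beyond the scatter. Compound 3 `O=C(NCCCOc1cccc(CN2CCCCC2)c1)Nc1cccc(Cl)c1` differs from compound 2 by 3-chlorophenyl in place of methyl on an amide-type nitrogen. Among the compounds with values here, the only measured step bearing on this runs the opposite way, where 3-(trifluoromethyl)phenyl gave way to methyl and the number fell; placing an aromatic ring back on that nitrogen is therefore expected to raise it. Compound 3 is expected to show a step of a 3.2-fold higher number from compound 2 to compound 3 (0.51 log units; beyond the scatter), with an estimated value of 500 nM, likely between 200 nM and 1500 nM.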

Compound 3, dissociation constant: 316 nM
Compound 3: the middle estimate sits 1.6-fold (0.20 log units) above what was measured; the measured number falls inside the stated range.
By their numbers in this assay, from the lowest: compound 2; then compound 3; then compound 1.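

In this assay, an aromatic ring on this amide-type nitrogen still costs binding when it carries 3-chloro, with a 2.0-fold higher number from compound 2 to compound 3 (0.31 log units; beyond the scatter), so methyl keeps the lowest number of the three. The ring's substituent also counts: chloro in place of trifluoromethyl on an aromatic carbon gives a 2.6-fold lower number from compound 1 to compound 3 (0.41 log units; beyond the scatter), so the ring's cost varies with what it carries. Nothing measured here explains either step.

Going by these compounds, how much of the rise belongs to the ring itself remains open. So does how a plain phenyl, a cyclohexyl or an ethyl on that nitrogen would compare.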